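The compounds below may be only part of what the source reports. "The series", "measured", "known", "first", "only" and "open" are said of these compounds alone.

In an assay on isolated protein for inhibition of protein kinase C theta type (Homo sapiens), read by TR-FRET, with a stated time of 2 h (on this read-out lower numbers stand for stronger inhibition and higher numbers for weaker inhibition), compound 3 `N#Cc1cnc(NCc2cnccc2C(F)(F)F)cc1NCC1CCOCC1` gives 400 nM, which places it second highest among the three numbers measured. Compound 1 `N#Cc1cnc(NCc2cnccc2C(F)(F)F)cc1NC[C@H]1C[C@@H](O)C1` gives 300 nM, and the step of a 1.3-fold higher number from compound 1 to compound 3 (0.12 log units; within the scatter) is small. Compound 2 `N#Cc1cnc(NCc2cnccc2C(F)(F)F)cc1NC1CCOCC1` gives 900 nM, and the step of a 2.3-fold lower number from compound 2 to compound 3 (0.35 log units; beyond the scatter) shows that a ring attached directly to the nitrogen gave a weaker result than the same ring one carbon further out. Compound 4 `N#Cc1cnc(NCc2cnccc2C(F)(F)F)cc1N[C@H]1CC[C@@H](C(N)=O)CC1` again puts a ring directly on that nitrogen: 4-carbamoylcyclohexyl in place of (oxan-4-yl)methyl on a nitrogen on an aromatic ring. The step of a 3.0-fold higher number from compound 1 to compound 2 (0.48 log units; beyond the scatter) points the same way. The expected step is therefore a modest rise, a 1.8-fold higher number from compound 3 to compound 4 (0.24 log units; within the scatter), and compound 4 is estimated at 700 nM, within 300 nM to 1800 nM.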

Compound 4, half-maximal inhibitory concentration: 7 nM
The estimate for compound 4 lay 100-fold (2.00 log units) above the measured number; measured number outside the range, below it.
By their numbers in this assay, from the lowest: compound 4; then compounds 1 and 3 (each within the scatter of the next); then compound 2.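

At this nitrogen, a ring attached directly can give the lowest number of the set: 4-carbamoylcyclohexyl in place of oxan-4-yl brings a 130-fold lower number from compound 2 to compound 4 (2.11 log units; beyond the scatter). The same group also brings a 57-fold lower number from compound 3 to compound 4 (1.76 log units; beyond the scatter) and a 43-fold lower number from compound 1 to compound 4 (1.63 log units; beyond the scatter), so direct ring attachment alone does not set a weak result. No supporting evidence explains this jump. Still open, going by these compounds, is which part of the new group matters, the carbamoyl or the cyclohexane ring. Plain cyclohexyl, or a carboxylic acid in place of the carbamoyl, would separate the two.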